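This account rests on a few compounds, and the source may have more. Where it says the series, first, only, none or still open, it means among the compounds named here.

Of the compounds shown here, three built on a shared core have been tested in a functional assay on MCF7 cells (Homo sapiens) for antiproliferative activity, read by MTT assay, with a stated time of 72 h; a lower number here means a stronger inhibitor, a higher number a weaker inhibitor. Compound 1 `CCOC(=O)c1oc2ccc(NS(=O)(=O)c3cccc(C)c3)cc2c1C` gives 101000 nM, and compound 2 `CCOC(=O)c1oc2ccc(NS(=O)(=O)c3cccc(Cl)c3)cc2c1C` gives 83900 nM; the step of a 1.2-fold lower number from compound 1 to compound 2 (0.08 log units; within the scatter) is small. Compound 3 `CCOC(=O)c1oc2ccc(NS(=O)(=O)c3ccccc3Cl)cc2c1C` reaches only a limit of the assay, > 200000 nM. Compound 3 thus stands at the limit of > 200000 nM in this assay, at which 1 of the 3 values shown sits, reached through the steps of an at least 1.9-fold higher number from compound 1 to compound 3 (0.29 log units; that floor lies within the scatter) and an at least 2.3-fold higher number from compound 2 to compound 3 (0.37 log units; beyond the scatter). Compound 4 `CCOC(=O)c1oc2ccc(NS(=O)(=O)c3cccs3)cc2c1C` alters compound 3 by thiophen-2-yl in place of 2-chlorophenyl on a sulfonyl sulfur, so the six-membered ring carrying chlorine gives way to a five-membered ring with one hetero atom. Since compound 1 and compound 2, which carry other rings on the sulfonyl sulfur, both sit below the limit, compound 4 is expected to return to a measurable value, estimated at 120000 nM within 50000 nM to 300000 nM. The expected step is an at least 1.6-fold lower number from compound 3 to compound 4 (0.22 log units; that floor lies within the scatter).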

Compound 4, half-maximal inhibitory concentration: 92300 nM
Beside the measured number, compound 4's estimate is 1.3-fold (0.11 log units) above it; the measured number falls inside the stated range.
By their numbers in this assay, from the lowest: compounds 2, 4 and 1 (each within the scatter of the next). At a limit, above all of these: compound 3.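

In this assay, a five-membered ring on the sulfonyl sulfur brings the number back from the limit, with an at least 2.1-fold lower number from compound 3 to compound 4 (0.33 log units; beyond the scatter). The thiophen-2-yl ring also cannot be told apart from the two other measurable rings, with a 1.1-fold higher number from compound 2 to compound 4 (0.04 log units; within the scatter) and a 1.1-fold lower number from compound 1 to compound 4 (0.04 log units; within the scatter). Compound 3 alone remains a limit and not a number: the limit of > 200000 nM in this assay, at which 1 of the 4 values shown sits.

Open, on these data alone, is whether any group on this sulfur can give a clearly lower number than these rings. A ring carrying an amine or a carboxylic acid, or a longer carbon chain in place of the ring, could test this.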